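A few compounds are considered here, and "the series" means these few. Any claim that something is new, unique, unknown or untested is made for them only; others in the source may bear on it.

Series notes, cytotoxicity on melanoma cells.

Measured so far:
compound 1, `CC1=CCC[C@H]2[C@](C)(CC3=CC(=O)C=C(NCC(=O)O)C3=O)[C@@H](C)CC[C@]12C`, gives 17800 nM in a functional assay on Fem-X cells (Homo sapiens) for cytotoxicity, read by MTT assay, with a stated time of 72 h; on this read-out higher numbers stand for weaker inhibition and lower numbers for stronger inhibition
compound 2, `CC(C)C[C@H](NC1=CC(=O)C=C(C(C)(C)C)C1=O)C(=O)O`, gives 39400 nM in this assay
compound 3, `CC1=CCC[C@H]2[C@](C)(CC3=CC(=O)C=C(N[C@@H](C(=O)O)C(C)C)C3=O)[C@@H](C)CC[C@]12C`, gives 11400 nM in this assay

Compound 2 gives the highest number of the three; its gaps to compound 1 and to compound 3 both lie beyond the usual scatter. Compound 1 and compound 3 share one core; compound 2 carries another, and the difference between the two cores is not broken down here.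

Within the first core, one change is measured: hydrogen in place of isopropyl on a saturated chain carbon bound to an amine nitrogen and a carbonyl carbon. It gives a 1.6-fold higher number from compound 3 to compound 1 (0.19 log units; within the scatter), so the isopropyl adds nothing clear on this core.

Compound 4, `C[C@H](NC1=CC(=O)C=C(C(C)(C)C)C1=O)C(=O)O`, is not yet measured. It stands to compound 2 as compound 1 stands to compound 3, by the same kind of change: hydrogen in place of isopropyl on a saturated chain carbon, two bonds along the chain from an amine nitrogen and a carbonyl carbon. The place is not the same, though: in the measured pair the carbon is bound to an amine nitrogen and a carbonyl carbon, here it lies two bonds along the chain from them.

Going on the step of a 1.6-fold higher number from compound 3 to compound 1 (0.19 log units; within the scatter) seen on the other core, the expected step is a 1.4-fold higher number from compound 2 to compound 4 (0.14 log units; within the scatter), a small change, with wide spread since only one earlier pair supports it. Compound 4 is thus expected to give about 55000 nM in this assay, between 25000 nM and 120000 nM.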

Compound 4, half-maximal inhibitory concentration: 20100 nM
Compound 4: the middle estimate sits 2.7-fold (0.44 log units) above what was measured, outside the stated range (below it).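

In this assay the change gives a 2.0-fold lower number from compound 2 to compound 4 (0.29 log units; within the scatter) and stays inside the scatter as a single step, but set beside the step on the other core it does not match: the same change on two cores in this assay, a 1.6-fold higher number (0.19 log units; within the scatter) from compound 3 to compound 1 and a 2.0-fold lower number (0.29 log units; within the scatter) from compound 2 to compound 4, 3.1-fold (0.49 log units) apart, beyond the scatter of two such steps

The step therefore cannot be carried from the core of compound 1 to the core of compound 2 as a fixed amount, and even its direction does not hold across the two pairs. Within the data shown here, this does not show that the core alone decides the outcome: there is only one pair per core, the carbon that changes is not in the same place in the two pairs, and the two effects cannot be separated.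

Still open, going by these compounds, is how the core of compound 2 and the core of compound 1 respond to other groups at this place, such as a longer chain, a phenyl ring or an amine. Also open, on these data alone, is whether an amide in place of the carboxylic acid would keep the values in this range.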